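A few compounds are considered here, and "the series" means these few. Any claim that something is new, unique, unknown or untested is made for them only; others in the source may bear on it.

For the measured compounds named here, in an ADME assay on L6 cells (Rattus norvegicus) for cytotoxicity, read by resazurin assay, with a stated time of 72 h (a lower number here means a stronger inhibitor, a higher number a weaker inhibitor), compound 3 `CN(C)C12CC(c3ccccc3)C(CN(CCCN3CCCC3)C1)C(c1ccccc1)C2` gives 1550 nM, the lowest of the three numbers so far, against compound 1 `CN(C)C12CC(c3ccccc3)C(CN(C(=O)CCN3CCCC3)C1)C(c1ccccc1)C2` at 11700 nM and compound 2 `CN(C)C12CC(c3ccccc3)C(CN(C(=O)CCN3CCCCC3)C1)C(c1ccccc1)C2` at 12400 nM. Compound 4 `CN(C)C12CC(c3ccccc3)C(CN(CCCN3CCCCC3)C1)C(c1ccccc1)C2` differs from compound 3 in one place: piperidin-1-yl in place of pyrrolidin-1-yl on a saturated chain carbon, three bonds along the chain from an amine nitrogen in a ring. The same ring swap has been measured once, on the carbonyl-bearing chain, and gave a 1.1-fold higher number from compound 1 to compound 2 (0.03 log units; within the scatter). Replacing that chain with the propyl chain gave larger steps, a 7.5-fold lower number from compound 1 to compound 3 (0.88 log units; beyond the scatter) and an 8.0-fold lower number from compound 2 to compound 3 (0.90 log units; beyond the scatter), but the chain stays unchanged here, so those steps offer little guidance. No step beyond the scatter is therefore expected in this assay. Compound 4 is estimated at about 1550 nM, with an expected range of 800 nM to 3000 nM.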

Compound 4, half-maximal inhibitory concentration: 1750 nM
Estimate against measurement, compound 4: 1.1-fold (0.05 log units) below, and the stated range covers the measured number.
By their numbers in this assay, from the lowest: compounds 3 and 4 (each within the scatter of the next); then compounds 1 and 2 (each within the scatter of the next).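

In this assay, the step of a 1.1-fold higher number from compound 3 to compound 4 (0.05 log units; within the scatter) shows that piperidin-1-yl can replace pyrrolidin-1-yl on the propyl chain without a change beyond the scatter. The chain step also holds with piperidin-1-yl at its end, giving a 7.1-fold lower number from compound 2 to compound 4 (0.85 log units; beyond the scatter) and a 6.7-fold lower number from compound 1 to compound 4 (0.83 log units; beyond the scatter). The ring swap therefore reads alike on both chains: the same change on two cores in this assay, a 1.1-fold higher number (0.03 log units; within the scatter) from compound 1 to compound 2 and a 1.1-fold higher number (0.05 log units; within the scatter) from compound 3 to compound 4, 1.1-fold (0.03 log units) apart, within the scatter of two such steps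

The compounds shown leave open whether a morpholin-4-yl ring or an open-chain dimethylamino group at the chain end would read the same way. They also leave open how a longer chain would read.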